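Cytotoxicity in the arylthio-acetanilide series: chloro to bromo

This account rests on a few compounds, and the source may have more. Where it says the series, first, only, none or still open, it means among the compounds named here.

Measured so far:
- compound 1 `Cc1ccc(-n2ccnc2SCC(=O)Nc2ccc(C)cc2Br)cc1`: 80800 nM
- compound 2 `COc1ccc(-n2ccnc2SCC(=O)Nc2ccccc2Br)cc1`: > 298000 nM
- compound 3 `Cc1ccc(-n2ccnc2SCC(=O)Nc2ccccc2Cl)cc1`: 33700 nM

In an ADME assay on MT4 cells (Homo sapiens) for cytotoxicity, read by MTT assay (a lower number here means that less compound is tolerated, a higher number that more compound is tolerated), compound 3 gives 33700 nM, the lowest of the two numbers available. Compound 1 gives 80800 nM in this assay. Compound 2 sits at a limit of this assay, > 298000 nM, and yields no number (the limit of > 298000 nM in this assay, at which 1 of the 3 values shown sits).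

Within the data shown here, the only step between numbers is a 2.4-fold lower number from compound 1 to compound 3 (0.38 log units; beyond the scatter), in which the anilide ring changes in two places at once. Compound 4 `Cc1ccc(-n2ccnc2SCC(=O)Nc2ccccc2Br)cc1` differs from compound 3 only as bromo in place of chloro on an aromatic carbon; the other part of the earlier step, loss of the methyl on that ring, is not separated out here. Compound 4 is also the methyl counterpart of compound 2, whose value is a limit and gives no size.

The earlier step was modest, and the present change is only part of it, so the step from compound 3 to compound 4 is expected to be small, toward a higher number, and is estimated as a 1.5-fold higher number from compound 3 to compound 4 (0.17 log units; within the scatter). Compound 4 is expected to give 50000 nM in this assay, within 20000 nM to 150000 nM.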

Compound 4, half-maximal cytotoxic concentration: 39300 nM
Compound 4: middle estimate off by 1.3-fold (0.10 log units), on the high side, within the range that was stated.
By their numbers in this assay, from the lowest: compounds 3 and 4 (each within the scatter of the next); then compound 1. At a limit, above all of these: compound 2.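

In this assay bromo in place of chloro on the anilide ring gives a 1.2-fold higher number from compound 3 to compound 4 (0.07 log units; within the scatter), so this exchange alone does not move the number beyond the scatter. The earlier two-place change can now be separated: hydrogen in place of methyl on that ring gives a 2.1-fold lower number from compound 1 to compound 4 (0.31 log units; beyond the scatter), so among compounds 1, 3 and 4 the difference beyond the scatter goes with the methyl and not with the halogen. Methyl in place of methoxy on an aromatic carbon gives an at least 7.5-fold lower number from compound 2 to compound 4 (0.87 log units; beyond the scatter), which is a bound and not a size, as compound 2 stands at a limit of this assay: the limit of > 298000 nM in this assay, at which 1 of the 4 values shown sits.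

From the compounds shown here alone, the true size of the methoxy step stays open, and each change rests on a single pair, so neither the methyl step nor the halogen exchange can be assumed to carry over to other members. Also open, going by these compounds, is how the number responds to an amine or a carboxylic acid on the anilide ring, or to fluoro or iodo in place of chloro.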